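The compounds below may be only part of what the source reports. "The series", "measured", "known", "first", "only" and "open" are said of these compounds alone.

Measured compounds:
- compound 1, `COc1cc(C(=O)Nc2cc(OC(F)(F)F)ccc2-n2cncn2)ccc1OC(C)C`: 890 nM
- compound 2, `COc1ccc(C(=O)Nc2cc(OC(F)(F)F)ccc2-n2cncn2)cc1OC`: 794 nM

Both compounds were tested in a functional assay on HEK cells for negative allosteric modulation of metabotropic glutamate receptor 7 (Rattus norvegicus), read by calcium flux (on this read-out lower numbers stand for stronger inhibition and higher numbers for weaker inhibition), and the two numbers sit within the usual scatter of each other: compound 2 gives 794 nM, and compound 1 gives 890 nM. Within the data shown here, the one step measured so far, a 1.1-fold lower number from compound 1 to compound 2 (0.05 log units; within the scatter), swaps one alkyl group for another on the same oxygen and changes nothing beyond the scatter.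

Compound 3, `CCOc1ccc(C(=O)Nc2cc(OC(F)(F)F)ccc2-n2cncn2)cc1OC`, is the unmeasured compound. It differs from compound 2 by methyl in place of hydrogen on a saturated chain carbon bound to an oxygen on an aromatic ring, so the methoxy becomes an ethoxy. Among the measured compounds shown here, the only step that bears on this change is the step from compound 1 to compound 2, which is also a change in the size of the alkyl group on that oxygen and which stayed within the scatter. On that basis a step of no size beyond the scatter is expected in this assay, with no preferred direction. The expected step is a 1.0-fold higher number from compound 2 to compound 3 (0.00 log units; within the scatter). Compound 3 is therefore estimated to give 800 nM, with a likely range from 350 nM to 1800 nM.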

Compound 3, half-maximal inhibitory concentration: 550 nM
Estimate against measurement, compound 3: 1.5-fold (0.16 log units) above; the range from low to high includes it.
By their numbers in this assay, from the lowest: compounds 3, 2 and 1 (each within the scatter of the next).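

In this assay the change from methoxy to ethoxy gives (a 1.4-fold lower number from compound 2 to compound 3 (0.16 log units; within the scatter)), and the change from the isopropyl group on that oxygen to the ethyl group gives (a 1.6-fold lower number from compound 1 to compound 3 (0.21 log units; within the scatter)). The earlier pair showed only that methyl and isopropyl on this oxygen read alike, whereas the ethyl group now fills the step between them, and all three compounds stay within the scatter of one another. At this place, then, adding or removing a single methyl on the saturated chain carbon bound to the oxygen has not yet moved the number beyond the scatter, and no supporting data bear on why the numbers stay so close.

Still open, on these data alone, is whether a longer chain such as butyl, or a chain ending in an amine or a carboxylic acid, on this oxygen would keep the number in the same range or shift it clearly. All three compounds also share the rest of the core, so they cannot say whether the same freedom on this oxygen would hold if another part of the molecule carried a different group.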